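The source may hold more compounds than are shown below. What is called first, only, known or untested is meant among the compounds shown, and "the series" means these compounds.

Working notes on the series. In an assay on isolated protein for inhibition of Indoleamine 2,3-dioxygenase 1 (Homo sapiens), read by fluorescence, with a stated time of 60 min (a lower number here means a stronger inhibitor, a higher number a weaker inhibitor), compound 1 `CS(=O)(=O)NNc1nonc1/C(=N/O)Nc1ccc(F)c(Br)c1` gives 609 nM, compound 2 `N=S1(=O)CC(Nc2nonc2/C(=N/O)Nc2ccc(F)c(Br)c2)C1` gives 208 nM and compound 3 `O=S(=O)(CCNc1nonc1/C(=N/O)Nc1ccc(F)c(Br)c1)N1CCC1` gives 191 nM. Compound 2 thus stands second highest of the three numbers: its nearest neighbour is compound 3, at a 1.1-fold lower number from compound 2 to compound 3 (0.04 log units; within the scatter), and its furthest is compound 1, from which it is reached by a 2.9-fold lower number from compound 1 to compound 2 (0.47 log units; beyond the scatter).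

Compound 4 `CN(C)S(=O)(=O)CCCNc1nonc1/C(=N/O)Nc1ccc(F)c(Br)c1` is the next step from compound 2. The change is a group of 9 heavy atoms (5 carbon, 1 nitrogen, 2 oxygen, 1 sulfur; no ring) in place of a group of 6 heavy atoms (3 carbon, 1 nitrogen, 1 oxygen, 1 sulfur; one four-membered non-aromatic ring with 1 hetero atom), on a nitrogen on an aromatic ring. Among the compounds with values here, two measured steps bear on it. The step of a 1.1-fold lower number from compound 2 to compound 3 (0.04 log units; within the scatter) shows that exchanging the ring-bearing group of compound 2 for a larger sulfonyl-linked chain ending in a ring leaves the number unchanged within scatter; the step of a 3.2-fold lower number from compound 1 to compound 3 (0.50 log units; beyond the scatter) shows that such a sulfonyl-linked chain reads modestly lower than the methanesulfonamido group. Compound 4 carries a sulfonyl-linked chain of the same size as that of compound 3, so no step beyond the scatter is expected; the estimate for the step is a 1.2-fold lower number from compound 2 to compound 4 (0.06 log units; within the scatter). Compound 4 is estimated at 180 nM, with a range from 80 nM to 400 nM.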

Compound 4, half-maximal inhibitory concentration: 97 nM
Compound 4: middle estimate off by 1.9-fold (0.27 log units), on the high side; the measured number falls inside the stated range.
By their numbers in this assay, from the lowest: compounds 4, 3 and 2 (each within the scatter of the next, the first and the last beyond it); then compound 1.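

In this assay, within the data shown here, 3-(dimethylsulfamoyl)propyl on the nitrogen on an aromatic ring is the first group to read beyond the scatter from the ring-bearing group it replaces (a 2.1-fold lower number from compound 2 to compound 4 (0.33 log units; beyond the scatter)), and it also reads beyond the scatter from methanesulfonamido (a 6.3-fold lower number from compound 1 to compound 4 (0.80 log units; beyond the scatter)). The two sulfonyl-linked chains are not separated (a 2.0-fold lower number from compound 3 to compound 4 (0.29 log units; within the scatter)), so the series shows no difference between the open dimethylsulfamoyl end with its propyl chain and the azetidine-bearing chain. No measurement available here accounts for these steps.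

The shown compounds do not separate the contributions of chain length and the group at the sulfonyl end, since both differ at once in the chain of compound 4. As far as these compounds go, it also remains open how a longer chain, or a carboxylic acid or an amine at the chain end, would read.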